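Swapping methoxy for benzyl on the aryl piperazine

The source may hold more compounds than are shown below. What is called first, only, known or untested is meant among the compounds shown, and "the series" means these compounds.

Measured compounds:
compound 1 `COc1ccccc1N1CCN(CCCNc2ncccc2C(=O)N(C)C)CC1`: 1.59 nM
compound 2 `COc1ccccc1N1CCN(CCCNc2ncccc2C(=O)C2CC2)CC1`: 0.501 nM
compound 3 `COc1ccccc1N1CCN(CCCSc2ccccc2C(=O)N(C)C)CC1`: 2 nM

In a functional assay for antagonist activity at Alpha-1A adrenergic receptor (Oryctolagus cuniculus) (on this read-out higher numbers stand for weaker binding and lower numbers for tighter binding), compound 1 gives 1.59 nM, the second highest of the three numbers. Within the data shown here, compound 3, at 2 nM, lies within the scatter of it, whereas the only single-point step measured is a 3.2-fold lower number from compound 1 to compound 2 (0.50 log units; beyond the scatter).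

Compound 4 `CN(C)C(=O)c1cccnc1NCCCN1CCN(c2ccccc2Cc2ccccc2)CC1` is not yet measured; it differs from compound 1 as follows: benzyl in place of methoxy on an aromatic carbon. Among the measured compounds shown here, the measured step from compound 1 to compound 2 concerns a cyclopropyl in place of dimethylamino on a carbonyl carbon, a different site, so no measured step bears on the present change. The expectation is therefore uncertain; a modest move toward a higher number, roughly at the edge of the scatter, is estimated as a 2.5-fold higher number from compound 1 to compound 4 (0.40 log units; beyond the scatter). Compound 4 is estimated at 4 nM, between 0.8 nM and 20 nM.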

Compound 4, dissociation constant: 6.31 nM
Compound 4: middle estimate off by 1.6-fold (0.20 log units), on the low side, and the stated range covers the measured number.
By their numbers in this assay, from the lowest: compound 2; then compounds 1 and 3 (each within the scatter of the next); then compound 4.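

In this assay, among these compounds, benzyl in place of methoxy on this aromatic carbon gives a 4.0-fold higher number from compound 1 to compound 4 (0.60 log units; beyond the scatter) and is the first measured change at this site. The step is beyond the usual scatter, so the swap does matter, yet a much larger group carrying an extra aromatic ring still leaves a measurable dissociation constant. Nothing available explains why the number rises.

Going by these compounds, whether a smaller group here, such as a hydroxyl or a fluorine, would stay closer to compound 1 remains open. So does whether benzyl would produce a similar step in compound 2, which has cyclopropyl on the carbonyl carbon.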